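Stilbene series: methoxy addition on the shared core

This account rests on a few compounds, and the source may have more. Where it says the series, first, only, none or still open, it means among the compounds named here.

Measured compounds in a functional assay on MDA-MB-468 cells (Homo sapiens) for antiproliferative activity, read by MTT assay; on this read-out higher numbers stand for weaker inhibition and lower numbers for stronger inhibition:
compound 1 `COc1ccc(/C=C/c2cc(OC)c(OC)c(OC)c2)c(O)c1`, 5300 nM
compound 2 `COc1cc(/C=C/c2ccc(OC)cc2O)cc(OC)c1`, 8400 nM
compound 3 `COc1cc(/C=C/c2cc(Br)ccc2O)cc(OC)c1`, 6100 nM

All three measured values in this assay lie within the usual scatter of one another, so no ranking among compounds 1, 2 and 3 is drawn. Within the data shown here, the one single-point change measured so far is methoxy in place of hydrogen on an aromatic carbon, which gave a 1.6-fold lower number from compound 2 to compound 1 (0.20 log units; within the scatter). The difference between the core of compound 2 and the core of compound 3 is not broken down here.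

Compound 4 `COc1cc(/C=C/c2cc(Br)ccc2O)cc(OC)c1OC` has not yet been measured. Among the measured compounds shown here, it differs from compound 3 by methoxy in place of hydrogen on an aromatic carbon, the same change as the one from compound 2 to compound 1, with the same surroundings of the place. The change from compound 2 to compound 1 itself stayed within the scatter. On that basis the step of a 1.5-fold lower number from compound 3 to compound 4 (0.18 log units; within the scatter) is expected to be of about that size. Compound 4 is therefore estimated at 4000 nM in this assay, with a likely range from 2000 nM to 9000 nM, resting only on compound 3 at 6100 nM and the earlier step.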

Compound 4, half-maximal inhibitory concentration: 14200 nM
Beside the measured number, compound 4's estimate is 3.6-fold (0.55 log units) below it; measured number above the stated range.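

Methoxy in place of hydrogen on an aromatic carbon, ortho to two methoxy groups and para to a large group, gave a 2.3-fold higher number from compound 3 to compound 4 (0.37 log units; beyond the scatter) in this assay, so on the core of compound 3 the change weakened inhibition by a modest margin. The change therefore cannot be carried from one core to the other in this series as a fixed step, as the two steps differ by more than the scatter allows: the same change on two cores in this assay, a 1.6-fold lower number (0.20 log units; within the scatter) from compound 2 to compound 1 and a 2.3-fold higher number (0.37 log units; beyond the scatter) from compound 3 to compound 4, 3.7-fold (0.57 log units) apart, beyond the scatter of two such steps

Among these compounds, this rests on only two pairs and shows that the outcome depends on the core for these compounds; it does not show which feature of the cores separates the two steps, nor does it give a rule for other cores.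

Open, from the compounds shown here alone, is whether an ethoxy group, a longer chain or an amine in the place of the added methoxy would read like compound 4 or like compound 3. Also open, going by these compounds, is whether chlorine or a nitrile in place of the bromine would alter the size of the step.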